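The source may report more compounds than this note shows. Statements on the series, on what has been measured and on what is new or still open speak of the compounds shown alone.

Measured so far in a physicochemical assay for solubility; on this read-out lower numbers stand for lower solubility and higher numbers for higher solubility:
Compound 1 `O=C(c1nc2c(C(F)(F)F)cc(-c3ccoc3)cn2c1Cl)N1CCC(N2CCCC2)CC1`: > 500000 nM, a limit
Compound 2 `CC1(C)COC(=O)N1C1CCN(C(=O)c2nc3c(C(F)(F)F)cc(-c4ccoc4)cn3c2Cl)CC1`: > 500000 nM, a limit

For compound 2 the read-out is only a limit, > 500000 nM. Both measured compounds sit there: the limit of > 500000 nM in this assay, at which 2 of the 2 values shown sit. Compound 3 `CC1(C)CN(C2CCN(C(=O)c3nc4c(C(F)(F)F)cc(-c5ccoc5)cn4c3Cl)CC2)C(=O)O1` has the same atoms as compound 2, joined differently: a group of 8 heavy atoms (5 carbon, 1 nitrogen, 2 oxygen; one five-membered non-aromatic ring with 2 hetero atoms) in place of a group of 8 heavy atoms (5 carbon, 1 nitrogen, 2 oxygen; one five-membered non-aromatic ring with 2 hetero atoms), on a saturated ring carbon. Among the measured compounds shown here, the only measured step that bears on this is a step that the two limits leave unreadable from compound 1 to compound 2, and it offers no size to carry over. In this assay the expected change is therefore none beyond the scatter, an estimated a number no higher from compound 2 to compound 3 (the limit leaves the size open). Compound 3 is expected to read about 500000 nM, with an estimated range of 200000 nM to 1000000 nM, quite likely again as a limit.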

Compound 3, solubility: > 500000 nM
Compound 3: a limit, no number; the forecaster's own chance of this, stated with the estimate: 75%; the middle value sits exactly at the limit.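

In this assay, among the compounds shown here, compound 3 gives > 500000 nM as a limit, so no step from compound 1 or compound 2 to it can be read. The compounds shown leave open whether compound 1, compound 2 and compound 3 differ at all on this read-out: the limit of > 500000 nM in this assay, at which 3 of the 3 values shown sit.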